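A few compounds are considered here, and "the series" means these few. Any claim that something is new, unique, unknown or untested is made for them only; others in the source may bear on it.

Measured so far in a functional assay on NCI-H23 cells (Homo sapiens) for inhibition, read by sulforhodamine B assay, with a stated time of 48 h, tested at 10 uM; on this read-out higher numbers stand for a weaker effect at the one concentration tested and lower numbers for a stronger effect:
compound 1 `COc1cc2cc(Oc3ccc(NC(=O)Nc4ccccc4)cc3)c(C)nc2cc1OC`, 87.2%
compound 2 `COc1cc2cc(Oc3ccc(NC(=O)Nc4ccc(C)cc4)cc3)c(C)nc2cc1OC`, 95.6%

For the measured compounds named here, compound 2 and compound 1 sit within the scatter of each other; the single change between them reads a number 8.4 percentage points higher from compound 1 to compound 2 (within the scatter).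

Compound 3 `COc1cc2cc(Oc3ccc(NC(=O)Nc4ccc(C(F)(F)F)cc4)cc3)c(C)nc2cc1OC` is not yet measured. It differs from compound 2 by trifluoromethyl in place of methyl on an aromatic carbon. Going by the values given here, the only measured step touching this position is the one from compound 1 to compound 2, and that stayed within the scatter. Among the compounds with values here, no measured step speaks to trifluoromethyl directly. In this assay no movement beyond the scatter is therefore expected; the expected step is a number 4.6 percentage points lower from compound 2 to compound 3 (within the scatter). Compound 3 is estimated at 91%, in the range 72% to 104%.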

Compound 3, a percentage reported as activity, at one concentration (the size of the read-out at that concentration, not a potency): 79.3%
Compound 3: middle estimate off by 11.7 percentage points, on the high side, and the stated range covers the measured number.
By their numbers in this assay, from the lowest: compounds 3, 1 and 2 (each within the scatter of the next, the first and the last beyond it).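

In this assay, this position can carry a change beyond the scatter: trifluoromethyl in place of methyl gives a number 16.3 percentage points lower from compound 2 to compound 3 (beyond the scatter) on the aromatic carbon para to a large group. Trifluoromethyl in place of hydrogen gives a number 7.9 percentage points lower from compound 1 to compound 3 (within the scatter) and so does not separate from the unsubstituted ring, leaving only the methyl and trifluoromethyl compounds apart. Nothing available accounts for this difference. As far as these compounds go, whether a chlorine, a methoxy group or a nitrile at the same carbon would follow trifluoromethyl or methyl stays open, as does whether the step holds at other concentrations.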